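Benzyl to 3,7-dimethylocta-2,6-dien-1-yl on the shared core

A few compounds are considered here, and "the series" means these few. Any claim that something is new, unique, unknown or untested is made for them only; others in the source may bear on it.

In a functional assay on HCC827 cells (Homo sapiens) for inhibition, read by fluorescence, with a stated time of 72 h (on this read-out higher numbers stand for weaker inhibition of growth and lower numbers for stronger inhibition of growth), compound 1 `CC(C)CCn1cnc2c(Nc3cccc(Cl)c3)nc(N[C@H]3CC[C@H](N)CC3)nc21` gives 10300 nM, compound 2 `CCCCn1cnc2c(Nc3cccc(Cl)c3)nc(N[C@H]3CC[C@H](N)CC3)nc21` gives 7200 nM and compound 3 `N[C@H]1CC[C@H](Nc2nc(Nc3cccc(Cl)c3)c3ncn(Cc4ccccc4)c3n2)CC1` gives 13700 nM. Compound 3 thus stands level with both others, all three numbers lying within the scatter of one another. Compound 4 `CC(C)=CCC/C(C)=C/Cn1cnc2c(Nc3cccc(Cl)c3)nc(N[C@H]3CC[C@H](N)CC3)nc21` differs from compound 3 by 2,6-dimethylhepta-1,5-dien-1-yl in place of phenyl on a saturated chain carbon bound to an aromatic nitrogen. Two measured steps changed this same place, a 1.3-fold higher number from compound 1 to compound 3 (0.12 log units; within the scatter) and a 1.9-fold higher number from compound 2 to compound 3 (0.28 log units; within the scatter), and a 1.4-fold lower number from compound 1 to compound 2 (0.16 log units; within the scatter) altered the chain itself. None of them exceeds the scatter, so no step beyond it is expected in this assay. The estimated step is a 1.5-fold lower number from compound 3 to compound 4 (0.18 log units; within the scatter). Compound 4 is expected at 9000 nM, with an estimated range from 3500 nM to 20000 nM.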

Compound 4, concentration for 50% growth inhibition: 18200 nM
The estimate for compound 4 lay 2.0-fold (0.31 log units) below the measured number; measured number inside the range.
By their numbers in this assay, from the lowest: compounds 2, 1, 3 and 4 (each within the scatter of the next, the first and the last beyond it).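

In this assay, for the compounds shown here, the 3,7-dimethylocta-2,6-dien-1-yl group gives the first step at this place that lies beyond the scatter, though only a modest one (a comparison that reads a 2.5-fold higher number from compound 2 to compound 4 (0.40 log units; beyond the scatter)). Against the other two chains the numbers stay within the scatter (a 1.3-fold higher number from compound 3 to compound 4 (0.12 log units; within the scatter) and a 1.8-fold higher number from compound 1 to compound 4 (0.25 log units; within the scatter)), so this group cannot be told apart from benzyl or from the branched chain of compound 1. The place on a saturated chain carbon bound to an aromatic nitrogen therefore accepts this larger unbranched-ring-free group at the cost of that modest step alone.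

Going by these compounds, whether an amine or a carboxylic acid on this chain would move the number in either direction stays open. No evidence at hand accounts for the modest step.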